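Replacing Benzyl with Methyl at Selenium Across Two Cores

The compounds below may be only part of what the source reports. "The series", "measured", "known", "first", "only" and "open" are said of these compounds alone.

In a functional assay on HT-29 cells (Homo sapiens) for cytotoxicity, read by MTT assay, with a stated time of 72 h (on this read-out lower numbers stand for stronger inhibition of growth and higher numbers for weaker inhibition of growth), compound 1 `C[Se]/C(=N\C(=O)c1cccs1)NC(=O)c1cccs1` gives 0.34 nM. Compound 3 `O=C(/N=C(/NC(=O)c1cccs1)[Se]Cc1ccccc1)c1cccs1` gives 55100 nM, and compound 2 `O=C(/N=C(/NC(=O)c1ccno1)[Se]Cc1ccccc1)c1ccno1` gives 6820 nM. Compounds 1 and 3 share one core and differ in a single spot: hydrogen in place of phenyl on a saturated chain carbon bound to a selenium atom. That single change produced the step of a 160000-fold lower number from compound 3 to compound 1 (5.21 log units; beyond the scatter), one of the largest shifts a chemist could hope to see from so small an edit. Compound 2 carries a different core; how the two cores differ is not broken down here. Compound 4 `C[Se]/C(=N\C(=O)c1ccno1)NC(=O)c1ccno1` is built from compound 2 by the same change at the same place: hydrogen in place of phenyl on a saturated chain carbon bound to a selenium atom. Compound 4 has not yet been tested in this assay. Going by the values given here, because the measured pair showed a 160000-fold lower number from compound 3 to compound 1 (5.21 log units; beyond the scatter), a large step toward lower numbers is also expected here, though it rests on only one measured pair and a different core. The expected step from compound 2 to compound 4 is estimated as a 1400-fold lower number from compound 2 to compound 4 (3.13 log units; beyond the scatter). Compound 4 is expected to give about 5 nM, with a likely range from 0.1 nM to 300 nM.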

Compound 4, concentration for 50% growth inhibition: 0.79 nM
Estimate against measurement, compound 4: 6.3-fold (0.80 log units) above; the range from low to high includes it.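

In this assay, replacing benzyl with methyl on the selenium again lowers the number sharply on the second core, giving an 8600-fold lower number from compound 2 to compound 4 (3.94 log units; beyond the scatter), so the direction of the change carries over. Going by these compounds alone, the size of the step does not carry over unchanged, and the gap between the two steps is larger than repeated measurements would explain: the same change on two cores in this assay, a 160000-fold lower number (5.21 log units; beyond the scatter) from compound 3 to compound 1 and an 8600-fold lower number (3.94 log units; beyond the scatter) from compound 2 to compound 4, 19-fold (1.27 log units) apart, beyond the scatter of two such steps With only two pairs, this shows that the change works strongly on both of these cores, but it does not show how the core sets the size of the step, or what would happen on any other core.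

The compounds shown carry only benzyl or methyl on the selenium, so it stays open whether an ethyl group or a longer chain would keep the low numbers of compound 1 and compound 4 or lose them. Going by these compounds, it is equally open how such a chain would behave if it carried an amine or a carboxylic acid.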